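This account rests on a few compounds, and the source may have more. Where it says the series, first, only, none or still open, it means among the compounds named here.

Compound 1 `Cc1ccc(C(=O)CC(=O)c2cc3ccccc3s2)c(O)c1`, compound 2 `Cc1cc2oc(-c3cc4ccccc4s3)cc(=O)c2cc1Cl` and compound 3 `Cc1ccc(O)c(C(=O)CC(=O)c2cc3ccccc3s2)c1` were each examined in an ADME assay on PANC-1 cells (Homo sapiens) for inhibition, read by MTT assay, with a stated time of 90 h; on this read-out lower numbers stand for stronger inhibition of growth and higher numbers for weaker inhibition of growth. Compound 1 gives 9.24 ug/mL in this assay. Compound 3 gives 15.8 ug/mL in this assay. For compound 2 the result in this assay is a limit of the assay, > 100 ug/mL, and not a number. Of the two numbers recorded, compound 3 has the highest, and its nearest neighbour is compound 1, whose number sits a little lower; that gap lies within the scatter of such measurements, so the two compounds cannot be told apart by it. Among the compounds with values here, no pair of the measured compounds differs in a single place, so no step between measured values can be drawn from them.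

Compound 4 `O=C(CC(=O)c1ccccc1O)c1cc2ccccc2s1` has not yet been measured in this assay. It differs from compound 3 in one respect: hydrogen in place of methyl on an aromatic carbon. With only a methyl lost and a hydrogen gained, the expected step in this assay is a 1.0-fold higher number from compound 3 to compound 4 (0.01 log units; within the scatter), a shift that is not anticipated to reach beyond the scatter in either direction. Compound 4 is therefore estimated to give 16 ug/mL in this assay, with a range from 6 ug/mL to 40 ug/mL.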

Compound 4, concentration for 50% growth inhibition: 7.77 ug/mL
For compound 4 the middle estimate is 2.1-fold (0.31 log units) above the measured one; measured number inside the range.
By their numbers in this assay, from the lowest: compounds 4, 1 and 3 (each within the scatter of the next, the first and the last beyond it). At a limit, above all of these: compound 2.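

In this assay, hydrogen in place of methyl on this aromatic carbon, para to a hydroxy group and meta to a large group, gives a 2.0-fold lower number from compound 3 to compound 4 (0.31 log units; beyond the scatter) and so marks a modest change beyond the scatter, with the number falling once the methyl has gone; at this place, then, the methyl is not needed for the growth inhibition seen, and the compound without it inhibits growth more strongly. Read against the other compound that carries a methyl on this ring, the same exchange gives a 1.2-fold lower number from compound 1 to compound 4 (0.08 log units; within the scatter) and stays within the scatter, so there the loss of the methyl cannot be told from no change, and the effect of removing a methyl is not the same for the two methyl compounds. Nothing measured among these compounds accounts for either step.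

The compounds shown leave open whether another group on this aromatic carbon, such as a methoxy group, a chlorine atom or an amine, would move the number further in either direction. They also leave open what a carboxylic acid or a longer chain would do in place of the hydroxy group.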